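Removing the chloro from compound 3: an expected step

This account rests on a few compounds, and the source may have more. Where it says the series, first, only, none or still open, it means among the compounds named here.

The series shares one core, varied only on the aromatic ring. Compound 1 `COc1ccc(NC2=NCCC3(CCCCC3)S2)cc1` gives 1.45 in a physicochemical assay for lipophilicity, at pH 7.4; on this read-out higher numbers stand for higher lipophilicity and lower numbers for lower lipophilicity. Compound 2 `CC(=O)c1ccc(NC2=NCCC3(CCCCC3)S2)cc1` gives 1.88 in this assay, and the step of a number 0.43 log units higher from compound 1 to compound 2 (beyond the scatter) is the only measured step among these three. Compound 3 `Cc1ccc(NC2=NCCC3(CCCCC3)S2)cc1Cl` gives 0.91 in this assay, the lowest of the three numbers: compound 1 stands beyond the scatter above it, and compound 2 further still.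

Compound 4 `Cc1ccc(NC2=NCCC3(CCCCC3)S2)cc1` has not been measured. Its difference from compound 3 is hydrogen in place of chloro on an aromatic carbon. Going by the values given here, no measured step concerns the chloro; the step from compound 1 to compound 2 exchanges a different group, so it does not bear on this change, and the expectation rests only on the one heavy atom that leaves. Compound 4 is therefore expected to sit somewhat lower than compound 3, a step of a number 0.41 log units lower from compound 3 to compound 4 (beyond the scatter) in this assay. Among the compounds with values here, the estimate for compound 4 is 0.5, with a range from 0 to 1.1, held wide because no compound here shows the chloro alone.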

Compound 4, distribution coefficient: 1.48
Compound 4: middle estimate off by 0.98 log units, on the low side; the whole stated range lies below it.
By their numbers in this assay, from the lowest: compound 3; then compounds 1 and 4 (each within the scatter of the next); then compound 2.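

With the step of a number 0.57 log units higher from compound 3 to compound 4 (beyond the scatter) in this assay, the chloro, ortho to a methyl group, now has a measured exchange of its own, and here the compound with hydrogen, which has one heavy atom fewer, carries the higher number. Compound 4 also links the two other compounds by single exchanges: methyl in place of acetyl gives a number 0.40 log units lower from compound 2 to compound 4 (beyond the scatter) on this read-out, while methyl in place of methoxy gives a number 0.03 log units higher from compound 1 to compound 4 (within the scatter) and so separates the two groups by no more than the scatter. Nothing measured here explains the direction of the chloro step.

Whether the chloro step keeps its direction and size elsewhere stays open, as no compound shown carries the chloro without that methyl group. On these data alone, how an amine, a carboxylic acid or a longer chain would read on this aromatic carbon also stays open.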